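The compounds below may be only part of what the source reports. "The series", "measured", "known", "first", "only" and "open" are said of these compounds alone.

Measured so far:
- compound 1 `CCOc1cc(NC(=O)C2(NC(=O)c3ccc4c(C5CCCC5)c(-c5ncc(Cl)cn5)n(C)c4c3)CCC2)ccc1/C=C/C(=O)OCOP(=O)(O)OC(C)(C)C`: 1.48 h
- compound 2 `CCOc1cc(NC(=O)C2(NC(=O)c3ccc4c(C5CCCC5)c(-c5ncc(Cl)cn5)n(C)c4c3)CCC2)ccc1/C=C/C(=O)OCOP(=O)(O)O`: 0.167 h

Among the compounds with values here, in an ADME assay (liver) for pharmacokinetics, with Liver microsome (Homo sapiens) as the target, using microsomes (on this read-out lower numbers stand for a shorter-lived compound and higher numbers for a longer-lived compound), compound 2 gives the lowest of the two numbers on record; its nearest neighbour is compound 1, and the only measured step, an 8.9-fold lower number from compound 1 to compound 2 (0.95 log units; beyond the scatter), runs from that neighbour down to compound 2.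

Compound 3 `CCOC(=O)/C=C/c1ccc(NC(=O)C2(NC(=O)c3ccc4c(C5CCCC5)c(-c5ncc(Cl)cn5)n(C)c4c3)CCC2)cc1OCC` differs from compound 2 by one carbon atom in place of a group of 5 heavy atoms (4 oxygen, 1 phosphorus; no ring), on a saturated chain carbon bound to an oxygen next to a carbonyl group. Within the data shown here, the one measured step bears on this change only loosely: it alters the same group in compound 1 by removing a tert-butyl from an oxygen and shortens the half-life, whereas the step to compound 3 removes that group altogether and puts a methyl in its place. Among the measured compounds shown here, no measured pair shows removal of the whole group, so the direction of the step in this assay cannot be read from the data. The step from compound 2 to compound 3 is therefore estimated as a 6.0-fold higher number from compound 2 to compound 3 (0.78 log units; beyond the scatter), with wide uncertainty. For compound 3 the expected value in this assay is 1 h, within a range from 0.25 h to 4 h.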

Compound 3, half-life: > 5 h
Compound 3: a limit, no number; the forecaster's own chance of this, stated with the estimate: 10%; middle value at least 5.0-fold (0.69 log units) away from the limit.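

In this assay, the earlier step only removed tert-butyl from the phosphorus-bearing group, whereas compound 3 shows that group replaced in full by methyl, on a saturated chain carbon bound to an oxygen next to a carbonyl group: an at least 29-fold higher number from compound 2 to compound 3 (1.47 log units; beyond the scatter). Measured against the tert-butyl-bearing group, the same position gives an at least 3.3-fold higher number from compound 1 to compound 3 (0.52 log units; beyond the scatter), so compound 3 lies beyond the scatter from both phosphorus-bearing compounds, and both steps are open-ended. On these data alone, compound 3 reaches a limit and not a number, so the full size of both steps stays unknown: the limit of > 5 h in this assay, at which 1 of the 3 values shown sits.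

A single methyl replacement cannot show how far this half-life depends on the group that enters. A carboxylic acid at this end, or a longer chain in place of methyl, would test whether the result extends beyond compound 3.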